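The source may hold more compounds than are shown below. What is called first, only, known or untested is meant among the compounds shown, and "the series" means these compounds.

Measured in a physicochemical assay for lipophilicity, read by HPLC, measured as chromatographic lipophilicity, at pH 7.4; a higher number here means a more lipophilic compound, a lower number a more polar compound:
- compound 1 `O=C(C1CCN(C(=O)C(F)(F)F)CC1)N1N=CCC1c1ccccc1`: 4.9
- compound 2 `O=C(c1c[nH]nn1)N1CCC(C(=O)N2N=CCC2c2ccccc2)CC1`: 2
- compound 3 `O=C(c1cocn1)N1CCC(C(=O)N2N=CCC2c2ccccc2)CC1`: 2.9

Compound 3, at 2.9, stands second highest of the three, with compound 2 nearest to it. Compound 4 `O=C(c1cc[nH]n1)N1CCC(C(=O)N2N=CCC2c2ccccc2)CC1` carries 1H-pyrazol-3-yl in place of 1,3-oxazol-4-yl on a carbonyl carbon.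

The closest evidence is the modest a number 0.90 log units higher from compound 2 to compound 3 (beyond the scatter), which exchanges one ring for another at this same place. The large steps of a number 2.90 log units lower from compound 1 to compound 2 (beyond the scatter) and a number 2.00 log units lower from compound 1 to compound 3 (beyond the scatter) replace trifluoromethyl and say less. The entering group more closely resembles the 1H-1,2,3-triazol-4-yl of compound 2, so a lower number is expected, though only part of that modest step. The expected change is a number 0.40 log units lower from compound 3 to compound 4 (beyond the scatter). For compound 4 the estimated value is 2.5, with an expected range of 2.1 to 3.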

Compound 4, distribution coefficient: 2.4
Estimate against measurement, compound 4: 0.10 log units above; low and high end bracket the measured number.
By their numbers in this assay, from the lowest: compound 2; then compound 4; then compound 3; then compound 1.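

Exchanging one five-membered aromatic ring for another on this carbonyl carbon gives a number 0.50 log units lower from compound 3 to compound 4 (beyond the scatter) and a number 0.40 log units higher from compound 2 to compound 4 (beyond the scatter) in this assay so the three rings are all separated by more than the scatter. Compound 4 still remains far from the trifluoromethyl compound, with a number 2.50 log units lower from compound 1 to compound 4 (beyond the scatter) as the large step at this place. Nothing shown here accounts for these differences.

Going by these compounds, it remains open where an amine or a carboxylic acid on this carbonyl carbon would fall relative to these rings. On these data alone, whether the order of the three rings would hold on another core also remains open.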